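A Methoxy Added to a Series Sitting at the Limit

This account rests on a few compounds, and the source may have more. Where it says the series, first, only, none or still open, it means among the compounds named here.

Measured compounds:
compound 1 `O=c1ccoc2cc(OCc3cn(Cc4ccccc4)nn3)ccc12` — > 100000 nM
compound 2 `O=c1ccoc2cc(OCc3cn(Cc4cccc(F)c4)nn3)ccc12` — > 100000 nM
compound 3 `N#Cc1ccc(Cn2cc(COc3ccc4c(=O)ccoc4c3)nn2)cc1` — > 100000 nM

In a functional assay on A549 cells (Homo sapiens) for cytotoxicity, read by MTT assay, with a stated time of 48 h (a lower number here means a stronger inhibitor, a higher number a weaker inhibitor), compound 1 gives > 100000 nM, which is a limit of the assay and not a number. Compound 2 gives > 100000 nM, also a limit. Compound 3 gives > 100000 nM, again a limit. The three steps among them, a step that the two limits leave unreadable from compound 1 to compound 2, a step that the two limits leave unreadable from compound 1 to compound 3 and a step that the two limits leave unreadable from compound 2 to compound 3, cannot be sized, since every one of the measured values sits at the same limit: the limit of > 100000 nM in this assay, at which 3 of the 3 values shown sit.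

Compound 4 `COc1ccc(Cn2cc(COc3ccc4c(=O)ccoc4c3)nn2)cc1` is not yet measured in this assay. Against compound 1 it differs by methoxy in place of hydrogen on an aromatic carbon, which, read one bond further out, is benzyl to 4-methoxybenzyl. Among the compounds with values here, no measured step bears on this change directly; the only guidance is that fluoro and cyano on the same benzyl each left the value at the limit (the limit of > 100000 nM in this assay, at which 3 of the 3 values shown sit).

Compound 4 is therefore expected to show no step beyond the scatter, that is a step that the limit leaves unreadable from compound 1 to compound 4, with a high chance that only a limit is again reported. Compound 4 is estimated at 150000 nM, within a range from 60000 nM to 500000 nM.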

Compound 4, half-maximal inhibitory concentration: 16500 nM
Compound 4: middle estimate off by 9.1-fold (0.96 log units), on the high side; the measured number lies below the stated range.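

In this assay, within the data shown here, methoxy in place of hydrogen on an aromatic carbon, para to a large group, gives an at least 6.0-fold lower number from compound 1 to compound 4 (0.78 log units; beyond the scatter), and compound 4 is the first compound to return a number and not a limit. The group at this place on the benzyl therefore decides whether the value leaves the limit, as methoxy in place of cyano gives an at least 6.0-fold lower number from compound 3 to compound 4 (0.78 log units; beyond the scatter), while the change from 3-fluorophenyl to 4-methoxyphenyl gives an at least 6.0-fold lower number from compound 2 to compound 4 (0.78 log units; beyond the scatter). All three steps give only a smallest possible size, and the steps among compound 1, compound 2 and compound 3 still cannot be read, because of where those three values sit: the limit of > 100000 nM in this assay, at which 3 of the 4 values shown sit.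

What the compounds shown leave open is whether methoxy is special at this place, or whether a hydroxyl, an ethoxy or an amine on the same aromatic carbon would move the value as far or further. They also leave open how the true size of the gain compares with these smallest sizes, and whether a second substituent on the benzyl would lower the number again.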